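The source may hold more compounds than are shown below. What is called first, only, known or untested is meant among the compounds shown, and "the series" means these compounds.

The three measured compounds share one core and were all tested in a functional assay on the whole organism for inhibition, with Rattus norvegicus as the target, at a dose of 25 mg/kg by the intraperitoneal route; a higher number here means more inhibition at the dose given (going by the name of the read-out), a lower number less inhibition. Compound 1 `CN(C)c1ncnc2c1ncn2Cc1ccc([N+](=O)[O-])cc1` gives 0% in this assay, and compound 2 `CC(=O)Nc1ccc(Cn2cnc3c(N(C)C)ncnc32)cc1` gives 0%. For the measured compounds named here, the only step known between two compounds that differ in a single place is no change at the digits printed from compound 1 to compound 2 (within the scatter), and it concerns acetamido in place of nitro on an aromatic carbon, not the part of the molecule changed here. Compound 3 `CC(C)N(C)c1ncnc2c1ncn2CC1CC1` gives 32% in this assay, the highest of the three numbers, standing beyond the scatter above both compound 1 and compound 2.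

Compound 4 `c1nc(NC2CCC2)c2ncn(CC3CC3)c2n1` has not yet been measured. Its difference from compound 3 is cyclobutylamino in place of isopropyl(methyl)amino on an aromatic carbon. Going by the values given here, no measured step touches this position, and the single known step showed no movement beyond the scatter, so it offers no direction for the present change. With only this to go on, the step expected in this assay is a number 4 percentage points lower from compound 3 to compound 4 (within the scatter), small and of uncertain sign, and the range around it must be wide. Compound 4 is therefore estimated at 28% in this assay, with a likely span from 5% to 55%.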

Compound 4, a percentage reported as inhibition, in the whole organism at one dose (the size of the read-out at that dose, not a potency): 0%
For compound 4 the middle estimate is 28 percentage points above the measured one; the measured number lies below the stated range.
By their numbers in this assay, from the lowest: compounds 1, 2 and 4 (each within the scatter of the next); then compound 3.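

In this assay, cyclobutylamino in place of isopropyl(methyl)amino on an aromatic carbon gives a number 32 percentage points lower from compound 3 to compound 4 (beyond the scatter), the first step seen at this position and one beyond the usual scatter. This shows that the read-out at this dose can depend heavily on the group at this carbon, even when the swap keeps the same count of heavy atoms, the same mix of carbon and nitrogen, and no net charge. What differs between the two groups is that cyclobutylamino brings a four-membered ring and a hydrogen-bond donor, but no measurement here explains the drop.

The ring and the donor arrive together, so the compounds shown leave open which of them goes with the step: cyclobutyl(methyl)amino would keep the ring without the amine hydrogen, while isopropylamino would keep the amine hydrogen without the ring. Also open, from the compounds shown here alone, is how a larger ring joined through its nitrogen, such as piperidine, would behave at this position, with the cyclopropylmethyl group of compound 3 kept in place.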